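A few compounds are considered here, and "the series" means these few. Any claim that something is new, unique, unknown or untested is made for them only; others in the source may bear on it.

Compound 2 `COc1ccc(N2CCN(C(=S)SCc3ccc(C(=O)Nc4ccccc4N)cc3)CC2)cc1`: 39.4%
Compound 1 `CN(C(=S)SCc1ccc(C(=O)Nc2ccccc2N)cc1)c1cccnc1`: 16%

Both were tested in a functional assay on HeLa cells (Homo sapiens) for antiproliferative activity, read by CCK-8 assay, with a stated time of 72 h, tested at 2 uM; on this read-out higher numbers stand for a stronger effect at the one concentration tested and lower numbers for a weaker effect. Compound 2 gives 39.4%, while compound 1 gives 16%. Among the measured compounds shown here, that gap is beyond the usual scatter, so compound 2 stands higher of the two numbers known so far. Compound 3 `Nc1ccccc1NC(=O)c1ccc(CSC(=S)N2CCN(c3ccccc3F)CC2)cc1` has not yet been measured. It differs from compound 2 in one place: 2-fluorophenyl in place of 4-methoxyphenyl on an amine nitrogen in a ring. For the measured compounds named here, no pair of measured compounds shows exactly this change, so its direction cannot be read from the data; the entering group is smaller and brings no hydrogen-bond acceptor, but what that means for the read-out is simply unknown. A small step in either direction, or none beyond the scatter, is plausible. For compound 3 the expected step is a number 7.4 percentage points lower from compound 2 to compound 3 (within the scatter). Compound 3 is therefore estimated at 32%, within a range from 15% to 50%.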

Compound 3, a percentage reported as inhibition, at one concentration (the size of the read-out at that concentration, not a potency): 17.5%
Compound 3: the middle estimate sits 14.5 percentage points above what was measured; measured number inside the range.
By their numbers in this assay, from the lowest: compounds 1 and 3 (each within the scatter of the next); then compound 2.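

In this assay the step is a number 21.9 percentage points lower from compound 2 to compound 3 (beyond the scatter) when 2-fluorophenyl replaces 4-methoxyphenyl on the amine nitrogen in the ring. This shows that the read-out responds to what this aromatic ring carries, even though both groups contain one six-membered aromatic ring of carbon only. Nothing available here gives a reason for this step.

The change swaps both the kind of group on the aromatic ring and its place, so the compounds shown do not separate the loss of the methoxy group from the arrival of the fluorine, or either of these from the change of place. On these data alone, how a plain phenyl, a 2-methoxyphenyl or a 4-fluorophenyl on the same nitrogen would read remains open.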